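A few compounds are considered here, and "the series" means these few. Any claim that something is new, unique, unknown or untested is made for them only; others in the source may bear on it.

Among the compounds with values here, compound 1 `OC1CCCN(C(=S)Sc2c(-c3ccc(Br)cc3)[nH]c3ccccc23)C1` is the first member of this set; in a functional assay on U-373MG ATCC cells (Homo sapiens) for inhibition, read by MTT assay, with a stated time of 72 h (a lower number here means a stronger inhibitor of growth, a higher number a weaker inhibitor of growth), compound 1 gives 32000 nM. Compound 3 `OC1CCCN(C(=S)Sc2c(-c3ccc(Br)cc3)[nH]c3ccc(Cl)cc23)C1` differs from compound 1 by chloro in place of hydrogen on an aromatic carbon, and the measured step is a 1.2-fold higher number from compound 1 to compound 3 (0.09 log units; within the scatter). Compound 2 `CCOC(=O)C1CCN(C(=S)Sc2c(-c3ccc(Br)cc3)[nH]c3ccccc23)CC1` has a different core from compound 1; the difference between the two cores is not broken down here. In this assay compound 2 gives 35000 nM and compound 3 gives 39000 nM, all three values sitting within the scatter of one another. Within the data shown here, compound 4 `CCOC(=O)C1CCN(C(=S)Sc2c(-c3ccc(Br)cc3)[nH]c3ccc(Cl)cc23)CC1`, not yet measured, differs from compound 2 by chloro in place of hydrogen on an aromatic carbon, the same change at the same place as the one made from compound 1 to compound 3. For compound 4 the expected step is a 1.1-fold higher number from compound 2 to compound 4 (0.06 log units; within the scatter), because the earlier change gave a 1.2-fold higher number from compound 1 to compound 3 (0.09 log units; within the scatter). Compound 4 is therefore estimated at 40000 nM, with a likely range from 20000 nM to 80000 nM.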

Compound 4, concentration for 50% growth inhibition: 33000 nM
Compound 4: the middle estimate sits 1.2-fold (0.08 log units) above what was measured, within the range that was stated.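

In this assay, chloro in place of hydrogen on an aromatic carbon gives a 1.1-fold lower number from compound 2 to compound 4 (0.03 log units; within the scatter), so on the core of compound 2 the change stays within the scatter, as it does on the core of compound 1. The two steps agree: the same change on two cores in this assay, a 1.2-fold higher number (0.09 log units; within the scatter) from compound 1 to compound 3 and a 1.1-fold lower number (0.03 log units; within the scatter) from compound 2 to compound 4, 1.3-fold (0.11 log units) apart, within the scatter of two such steps. Within the data shown here, this shows only that a change with no readable effect on one core has none on the other; it does not show that a larger effect would carry across cores, and two pairs set no rule for the series.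

The compounds shown leave open whether a group other than chloro on that aromatic carbon, such as methoxy or nitrile, would give a step beyond the scatter on either core. Also open, as far as these compounds go, is how the change behaves when an amine or a carboxylic acid replaces the hydroxyl or the ethyl ester.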